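The compounds below may be only part of what the source reports. "The series", "measured", "known", "first", "only" and "open" are said of these compounds alone.

Measured so far in a functional assay on QGY-7703 cells (Homo sapiens) for cytotoxicity, read by MTT assay, with a stated time of 24 h (a higher number here means a weaker inhibitor, a lower number a stronger inhibitor), are two compounds:
- compound 1 `CN1C/C(=C\c2ccc(C(F)(F)F)cc2)C(=O)/C(=C/c2cccnc2)C1` gives 1660 nM
- compound 2 `O=C1/C(=C/c2cccnc2)CNC/C1=C\c1ccccc1F` gives 8890 nM

Compound 2 holds the higher of these two numbers, and its gap to compound 1 lies beyond the scatter. Compound 3 `O=C1/C(=C/c2cccnc2)CN(S(=O)(=O)c2ccc(Cl)cc2)C/C1=C\c1ccccc1F` has not yet been measured. It differs from compound 2 by a single change (4-chlorophenyl)sulfonyl in place of hydrogen on an amine nitrogen in a ring and carries (4-chlorophenyl)sulfonyl in place of hydrogen on an amine nitrogen in a ring. Among the measured compounds shown here, no measured pair shows this change. For the measured compounds named here, the only hint is compound 1 at 1660 nM where that nitrogen also carries no hydrogen, though it differs elsewhere too. A modest move towards a stronger inhibitor in this assay is therefore expected, with an estimated 3.6-fold lower number from compound 2 to compound 3 (0.55 log units; beyond the scatter) on this weak basis. For compound 3 the expected value is 2500 nM with an estimated range from 700 nM to 8000 nM around it.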

Compound 3, half-maximal inhibitory concentration: 12100 nM
Compound 3: the middle estimate sits 4.8-fold (0.68 log units) below what was measured, and the stated range ends below it.
By their numbers in this assay, from the lowest: compound 1; then compounds 2 and 3 (each within the scatter of the next).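

In this assay, among the compounds shown here, the pair gives the first direct reading at the amine nitrogen in the ring: (4-chlorophenyl)sulfonyl in place of hydrogen gives a 1.4-fold higher number from compound 2 to compound 3 (0.13 log units; within the scatter). Compound 2 and compound 3 therefore cannot be told apart in this assay, even though the new group brings 10 heavy atoms and one six-membered aromatic ring to that nitrogen. No measurement at hand offers an explanation for this result.

The compounds shown leave open whether an acetyl or a benzyl group on this nitrogen, with the rest of compound 2 unchanged, would also read the same as hydrogen. They also leave open whether a sulfonyl group carrying a methoxyphenyl or a simple methyl in place of the 4-chlorophenyl would do so.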